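The source may report more compounds than this note shows. Statements on the series, on what has been measured and on what is new or still open speak of the compounds shown alone.

Working notes on the series. In a functional assay on ECa-109 cells for inhibition, with ECa-109 cell line (Homo sapiens) as the target, read by sulforhodamine B assay (on this read-out lower numbers stand for stronger inhibition and higher numbers for weaker inhibition), compound 1 `Cc1ccc(NC2=CC(=O)c3c(nc4n3[C@H]3OC[C@@H](O)[C@H]3OC4)C2=O)cc1C` gives 4090 nM and compound 2 `O=C1C(Nc2ccccc2)=CC(=O)c2c1nc1n2[C@H]2OC[C@@H](O)[C@H]2OC1` gives 3560 nM; the step of a 1.1-fold lower number from compound 1 to compound 2 (0.06 log units; within the scatter). Compound 3 `O=C1C(NCc2ccccc2)=CC(=O)c2c1nc1n2[C@H]2OC[C@@H](O)[C@H]2OC1` returns only a limit of the assay, > 8000 nM, in this assay (the limit of > 8000 nM in this assay, at which 1 of the 3 values shown sits). The steps of an at least 1.9-fold higher number from compound 1 to compound 3 (0.29 log units; that floor lies within the scatter) and an at least 2.2-fold higher number from compound 2 to compound 3 (0.35 log units; beyond the scatter) bear on the move away from benzyl. Compound 4 `O=C1C(Nc2cccc(F)c2)=CC(=O)c2c1nc1n2[C@H]2OC[C@@H](O)[C@H]2OC1` carries 3-fluorophenyl in place of benzyl on an amine nitrogen. Because the change runs opposite to an at least 2.2-fold higher number from compound 2 to compound 3 (0.35 log units; beyond the scatter), compound 4 is expected to return a number rather than a limit, near compound 2. The expected step is an at least 2.2-fold lower number from compound 3 to compound 4 (0.35 log units; beyond the scatter), a modest move toward stronger inhibition. Estimate for compound 4 in this assay: 3500 nM, with a range of 1500 nM to 8000 nM.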

Compound 4, half-maximal inhibitory concentration: 2370 nM
Compound 4: the middle estimate sits 1.5-fold (0.17 log units) above what was measured, and the stated range covers the measured number.
By their numbers in this assay, from the lowest: compounds 4, 2 and 1 (each within the scatter of the next). At a limit, above all of these: compound 3.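

Compound 3 stands at a limit of the assay, not a number, in this assay: the limit of > 8000 nM in this assay, at which 1 of the 4 values shown sits. The compounds with an aromatic ring directly on the amine nitrogen all return numbers, and 3-fluorophenyl in place of benzyl gives an at least 3.3-fold lower number from compound 3 to compound 4 (0.52 log units; beyond the scatter) as a floor only. Fluoro does not separate from hydrogen, with a 1.5-fold lower number from compound 2 to compound 4 (0.18 log units; within the scatter) here, nor does 3-fluorophenyl separate from 3,4-dimethylphenyl, with a 1.7-fold lower number from compound 1 to compound 4 (0.24 log units; within the scatter) here.

On these data alone, whether an amine or a carboxylic acid on the phenyl ring would move the number beyond the scatter stays open. As far as these compounds go, the full size of the benzyl step also stays open.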